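The source may report more compounds than this note shows. Statements on the series, on what has been measured and on what is new or still open speak of the compounds shown alone.

For the measured compounds named here, compound 1 `COc1ccc2nc(C)cc(OCC(=O)Nc3cc(C)cc(C)c3)c2c1` carries a 3,5-dimethylphenyl on its amide-type nitrogen and gives 26000 nM in a physicochemical assay for solubility, in phosphate buffer, measured as kinetic solubility, with a stated time of 1 h, at pH 7.4 (on this read-out lower numbers stand for lower solubility and higher numbers for higher solubility), the highest of the three numbers measured so far. Compound 2 `CSc1ccc2nc(C)cc(OCC(=O)Nc3cc(C)cc(C)c3)c2c1` gives 3000 nM, and compound 3 `CCCc1cc(OCC(=O)Nc2cc(C)cc(C)c2)c2cc(OC)ccc2n1` gives 12000 nM. The two measured steps are an 8.7-fold lower number from compound 1 to compound 2 (0.94 log units; beyond the scatter) and a 2.2-fold lower number from compound 1 to compound 3 (0.34 log units; beyond the scatter); both change a group on the shared core, and neither touches the amide-type nitrogen. Compound 4 `COc1ccc2nc(C)cc(OCC(=O)Nc3cc(C)nc(C)n3)c2c1` differs from compound 1 at exactly that place: 2,6-dimethylpyrimidin-4-yl in place of 3,5-dimethylphenyl on an amide-type nitrogen. Going by the values given here, no measured step bears directly on this change, so the expectation rests on the structures alone. Compound 4 is estimated to give 60000 nM, within a range from 20000 nM to 180000 nM. That estimate would mean a 2.3-fold higher number from compound 1 to compound 4 (0.36 log units; beyond the scatter), an expected rise beyond the scatter.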

Compound 4, solubility: 5000 nM
Beside the measured number, compound 4's estimate is 12-fold (1.08 log units) above it; measured number outside the range, below it.
By their numbers in this assay, from the lowest: compounds 2 and 4 (each within the scatter of the next); then compound 3; then compound 1.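

For the compounds shown here, putting 2,6-dimethylpyrimidin-4-yl in place of 3,5-dimethylphenyl on the amide-type nitrogen brings a 5.2-fold lower number from compound 1 to compound 4 (0.72 log units; beyond the scatter) in this assay, so this position, untouched by the earlier steps, also moves the read-out. Although this change adds hydrogen-bond acceptors and keeps the heavy-atom count, the number falls rather than rises. Nothing available accounts for that fall. Still open, from the compounds shown here alone, is where a pyridinyl ring or an unsubstituted phenyl on the same nitrogen would fall, and whether the pyrimidine swap would act alike on compound 2 with its methylsulfanyl group.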